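The source may hold more compounds than are shown below. What is called first, only, known or untested is meant among the compounds shown, and "the series" means these compounds.

Compound 1 `NC(=O)c1ccc(-c2cnc(CCCc3ccc(-c4ccccc4)cc3)o2)nc1` is the weaker of the two compounds that give a number in an assay for inhibition of Fatty-acid amide hydrolase 1 (Rattus norvegicus); on this read-out higher numbers stand for weaker inhibition and lower numbers for stronger inhibition: compound 1 gives 30000 nM. Compound 2 `O=C(CCc1ccc(Oc2ccccc2)cc1)c1ncc(C(F)(F)F)o1` gives 2 nM, a gap far beyond the usual scatter. Compound 3 `NC(=O)c1ccc(-c2cnc(C(O)CCc3ccc(-c4ccccc4)cc3)o2)nc1` reaches only the limit of this assay, > 1000 nM. The step that the limit leaves unreadable from compound 1 to compound 3 therefore cannot be read (the limit of > 1000 nM in this assay, at which 1 of the 3 values shown sits).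

Compound 4 `O=C(O)c1cccc(-c2cnc(CCCc3ccc(-c4ccccc4)cc3)o2)n1` differs from compound 1 by 6-carboxypyridin-2-yl in place of 5-carbamoylpyridin-2-yl on an aromatic carbon. Among the compounds with values here, no measured step describes this change, so no size or direction of step can be drawn from the data. For compound 4 a value near that of compound 1 is expected, 30000 nM with a range of 5000 nM to 150000 nM, which means an expected step of no change at the digits printed from compound 1 to compound 4 (within the scatter) within the scatter.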

Compound 4, inhibition constant: 10000 nM
The estimate for compound 4 lay 3.0-fold (0.48 log units) above the measured number; the measured number falls inside the stated range.
By their numbers in this assay, from the lowest: compound 2; then compound 4; then compound 1.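

Within the data shown here, at this aromatic carbon next to the ring oxygen, replacing 5-carbamoylpyridin-2-yl with 6-carboxypyridin-2-yl gives a 3.0-fold lower number from compound 1 to compound 4 (0.48 log units; beyond the scatter), the first readable change at this position. The step is modest, so this position tolerates the swap without loss of inhibition, but the core stays weak. Nothing shown here explains the step.

The swap changes both the group and its number on the pyridine, so the two effects cannot be separated. On these data alone, how 5-carboxypyridin-2-yl or 6-carbamoylpyridin-2-yl would read at this position stays open.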